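Phenyl for dichlorophenyl: a repeated step on a thiazole scaffold

The compounds below may be only part of what the source reports. "The series", "measured", "known", "first", "only" and "open" are said of these compounds alone.

Three compounds have been measured in a functional assay on U-87MG ATCC cells for antiproliferative activity against U-87 MG (Homo sapiens), read by MTT assay, with a stated time of 48 h, tested at 100 uM; on this read-out lower numbers stand for a stronger effect and higher numbers for a weaker effect at the one concentration tested:
Compound 1, `Cc1nc(-c2ccc(Cl)cc2)sc1C(=O)CSc1nc(-c2ccccc2)c(C#N)c(=O)[nH]1`, gives 11.4%.
Compound 2, `Cc1nc(-c2ccc(Cl)cc2)sc1C(=O)CSc1nc(-c2ccc(Cl)c(Cl)c2)c(C#N)c(=O)[nH]1`, gives 36.5%.
Compound 3, `COc1ccc(-c2nc(C)c(C(=O)CSc3nc(-c4ccc(Cl)c(Cl)c4)c(C#N)c(=O)[nH]3)s2)cc1`, gives 31.1%.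

The three share a core, and two single changes link them. One change is phenyl in place of 3,4-dichlorophenyl on an aromatic carbon, and it gave a number 25.1 percentage points lower from compound 2 to compound 1 (beyond the scatter). The other is methoxy in place of chloro on an aromatic carbon, and it gave a number 5.4 percentage points lower from compound 2 to compound 3 (within the scatter); by that move compound 3 and compound 2 are not told apart in this assay.

Compound 4, `COc1ccc(-c2nc(C)c(C(=O)CSc3nc(-c4ccccc4)c(C#N)c(=O)[nH]3)s2)cc1`, has not yet been measured. It differs from compound 3 by phenyl in place of 3,4-dichlorophenyl on an aromatic carbon. This is the same change that was made from compound 2 to compound 1: the group that leaves, the group that enters and the surroundings of the place are described in the same words in both cases. The only other way the two pairs differ is the one just described, (methoxy in place of chloro on an aromatic carbon), which lies in a distant part of the molecule and itself produced a step within the scatter.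

Within the data shown here, on that footing the step from compound 3 to compound 4 in this assay is expected to be a number 22.1 percentage points lower from compound 3 to compound 4 (beyond the scatter), of the same sign as the earlier one, because a number 25.1 percentage points lower from compound 2 to compound 1 (beyond the scatter) was seen for the same change and nothing among the measured compounds speaks against repeating it. Compound 4 is therefore estimated at 9%, with the range 0% to 22%.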

Compound 4, a percentage reported as activity, at one concentration (the size of the read-out at that concentration, not a potency): 10.9%
Beside the measured number, compound 4's estimate is 1.9 percentage points below it; the range from low to high includes it.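

In this assay, phenyl in place of 3,4-dichlorophenyl gave a number 20.2 percentage points lower from compound 3 to compound 4 (beyond the scatter), so the change carried from the core of compound 2 to the core of compound 3 with a step of the same sign and a similar size: the same change on two cores in this assay, a number 25.1 percentage points lower (beyond the scatter) from compound 2 to compound 1 and a number 20.2 percentage points lower (beyond the scatter) from compound 3 to compound 4, 4.9 percentage points apart, within the scatter of two such steps. The change of methoxy in place of chloro gave a number 0.5 percentage points lower from compound 1 to compound 4 (within the scatter), so compound 1 and compound 4 are not told apart, and the two phenyl compounds behave alike just as the two 3,4-dichlorophenyl compounds do: the same change on two cores in this assay, a number 5.4 percentage points lower (within the scatter) from compound 2 to compound 3 and a number 0.5 percentage points lower (within the scatter) from compound 1 to compound 4, 4.9 percentage points apart, within the scatter of two such steps. Among these compounds, this shows that the two changes add up cleanly across these four compounds, but it rests on only two cores that differ in a single distant group, at one concentration in one cell line, so it does not show that the step would hold on a more different core, and it gives no potency and no reason for the step.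

The compounds shown leave open whether both chlorines of the 3,4-dichlorophenyl are needed for the weaker effect, or whether a phenyl with a single chloro would fall with compound 2 or with compound 1. They also leave open how a fluoro, a methyl, an amine or a carboxylic acid on that phenyl would read in this assay.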